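A few compounds are considered here, and "the series" means these few. Any claim that something is new, unique, unknown or untested is made for them only; others in the source may bear on it.

Measured in a functional assay on PC-3 cells (Homo sapiens) for antiproliferative activity, read by MTT assay, with a stated time of 48 h; on this read-out lower numbers stand for stronger inhibition and higher numbers for weaker inhibition:
- Compound 1 `COc1cc(N(Cc2ccc(C)cc2)C(=O)CSc2nc3ccccc3s2)cc(OC)c1OC`: > 80000 nM, a limit of the assay and not a number
- Compound 2 `COc1ccc(CN(C(=O)CSc2nc3ccccc3s2)c2cc(OC)c(OC)c(OC)c2)cc1N=[N+]=[N-]`: 14400 nM
- Compound 3 `COc1ccc(CN(C(=O)CSc2nc3ccccc3s2)c2cc(OC)c(OC)c(OC)c2)cc1O`: 2110 nM

Compound 2 has the higher of the two actual numbers. The gap to its nearest neighbour is a 6.8-fold lower number from compound 2 to compound 3 (0.83 log units; beyond the scatter).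

Compound 4 `COc1ccc(CN(C(=O)CSc2nc3ccccc3s2)c2cc(OC)c(OC)c(OC)c2)cc1[N+](=O)[O-]` carries nitro in place of azido on an aromatic carbon, ortho to a methoxy group (nitro in place of azido on an aromatic carbon).

Among the measured compounds shown here, no measured step makes this exact swap. The closest is the change at the same carbon that gave compound 3, a 6.8-fold lower number from compound 2 to compound 3 (0.83 log units; beyond the scatter). The wider change of the whole benzyl-side ring gave an at least 5.5-fold lower number from compound 1 to compound 2 (0.74 log units; beyond the scatter). These show that the ring matters, but not which way nitro would push the number, so the expected step is a 1.2-fold lower number from compound 2 to compound 4 (0.08 log units; within the scatter), with no shift beyond the scatter. Compound 4 is estimated at 12000 nM, with an expected range of 3500 nM to 45000 nM.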

Compound 4, half-maximal inhibitory concentration: 26500 nM
Beside the measured number, compound 4's estimate is 2.2-fold (0.34 log units) below it; the range from low to high includes it.
By their numbers in this assay, from the lowest: compound 3; then compounds 2 and 4 (each within the scatter of the next). At a limit, above all of these: compound 1.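

In this assay, nitro and azido at this carbon are not told apart, with a 1.8-fold higher number from compound 2 to compound 4 (0.26 log units; within the scatter) as the step between them. Hydroxy at the same carbon does separate, with a 13-fold higher number from compound 3 to compound 4 (1.10 log units; beyond the scatter) as the step, so of these three groups only hydroxy stands apart beyond the scatter. Compound 1 is a limit of the assay and not a number, so an at least 3.0-fold lower number from compound 1 to compound 4 (0.47 log units; beyond the scatter) gives only a bound on what the 4-methoxy-3-nitrophenyl ring adds. Still open, going by these compounds, is whether an amine or a carboxylic acid at this carbon would read like hydroxy or like nitro.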